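A few compounds are considered here, and "the series" means these few. Any claim that something is new, unique, unknown or untested is made for them only; others in the source may bear on it.

In an in vitro ADME assay on microsomes from liver (Homo sapiens) for pharmacokinetics, read by LC-MS, with a stated time of 10 min, tested at 1 uM (on this read-out higher numbers stand for fast clearance and lower numbers for slow clearance), compound 1 `COc1ccc(NC(=O)[C@H]2CN(C)C[C@@H]2c2ccc(/C=C/C(=O)Nc3ccccc3N)cc2)cc1` gives 14 mL/min/kg, compound 2 `CN1C[C@H](C(=O)Nc2ccc(C3CC3)cc2)[C@@H](c2ccc(/C=C/C(=O)Nc3ccccc3N)cc2)C1` gives 12 mL/min/kg and compound 3 `CN1C[C@H](C(=O)Nc2ccc(F)cc2F)[C@@H](c2ccc(/C=C/C(=O)Nc3ccccc3N)cc2)C1` gives 12 mL/min/kg, which places compound 3 level with compound 2 and within the scatter of compound 1. Compound 4 `CN1C[C@H](C(=O)Nc2cccnc2)[C@@H](c2ccc(/C=C/C(=O)Nc3ccccc3N)cc2)C1` shares the core of compound 3, and the change is pyridin-3-yl in place of 2,4-difluorophenyl on an amide-type nitrogen. Among the compounds with values here, no measured compound carries a pyridin-3-yl, so the evidence is indirect. It comes from three swaps in the group on the amide-type nitrogen: a 1.2-fold lower number from compound 1 to compound 2 (0.07 log units; within the scatter), a 1.2-fold lower number from compound 1 to compound 3 (0.07 log units; within the scatter) and no change at the digits printed from compound 2 to compound 3 (within the scatter), all within the scatter. With steps this small, the expected result is no shift beyond the scatter, in either direction: no change at the digits printed from compound 3 to compound 4 (within the scatter). The estimate for compound 4 is 12 mL/min/kg, with an expected range from 7 mL/min/kg to 21 mL/min/kg.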

Compound 4, clearance: 10 mL/min/kg
The estimate for compound 4 lay 1.2-fold (0.08 log units) above the measured number; measured number inside the range.
By their numbers in this assay, from the lowest: compounds 4, 2, 3 and 1 (each within the scatter of the next).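

In this assay pyridin-3-yl on the amide-type nitrogen brings a ring with a hetero atom and a hydrogen-bond acceptor to this position, yet all three comparisons stay within the scatter (a 1.2-fold lower number from compound 3 to compound 4 (0.08 log units; within the scatter)) (a 1.2-fold lower number from compound 2 to compound 4 (0.08 log units; within the scatter)) (a 1.4-fold lower number from compound 1 to compound 4 (0.15 log units; within the scatter)). This position has now held both carbon-only rings and a ring containing nitrogen with no step beyond the scatter. No measured property is available to explain these small steps. The compounds shown leave open whether an amine, a carboxylic acid or a longer chain on this nitrogen would move clearance beyond the scatter.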